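Halogen exchange on the fused ring of compound 1

This account rests on a few compounds, and the source may have more. Where it says the series, first, only, none or still open, it means among the compounds named here.

Compound 1 `COc1ccc2c(C3CCc4ccc(Cl)cc43)ncnc2c1OC` carries the lowest number of the three measured in an assay on isolated protein for inhibition of dual specificity calcium/calmodulin-dependent 3',5'-cyclic nucleotide phosphodiesterase 1B (Homo sapiens) (a lower number here means a stronger inhibitor, a higher number a weaker inhibitor), where compound 1 gives 4 nM. Compound 3 `COc1ccc2c(N3C[C@H](C)C[C@H](C)C3)ncnc2c1OC` comes nearest, with 70 nM in this assay, a gap beyond the scatter. Compound 2 `COc1cc2ncnc(C(C)c3cccc(Cl)c3)c2cc1OC` stands furthest, at 230 nM in this assay; this gap to compound 1 also lies beyond the scatter. Among the measured compounds shown here, no pair among the measured compounds differs in a single place, so no measured step is available.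

Compound 4 `COc1ccc2c(C3CCc4ccc(F)cc43)ncnc2c1OC` differs from compound 1 by fluoro in place of chloro on an aromatic carbon. For the measured compounds named here, nothing among the measured compounds shows what this exchange does. Compound 1, at 4 nM, leaves room for movement in either direction. The step from compound 1 to compound 4 is expected to be a small loss, close to the scatter, so a 2.5-fold higher number from compound 1 to compound 4 (0.40 log units; beyond the scatter) is the expectation. Compound 4 is estimated at 10 nM in this assay, with a range from 3 nM to 35 nM.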

Compound 4, half-maximal inhibitory concentration: 38 nM
For compound 4 the middle estimate is 3.8-fold (0.58 log units) below the measured one, outside the stated range (above it).
By their numbers in this assay, from the lowest: compound 1; then compounds 4 and 3 (each within the scatter of the next); then compound 2.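

Among the compounds shown here, the step from chloro to fluoro is the first single-place comparison. In this assay it gives a 9.5-fold higher number from compound 1 to compound 4 (0.98 log units; beyond the scatter), so this aromatic carbon of the fused ring system is sensitive to the identity of the halogen, and chloro is the better of the two halogens tested here. Nothing available accounts for this difference between chloro and fluoro.

With only two substituents at this carbon, the compounds shown cannot tell whether bromo, methyl, nitrile or plain hydrogen would match compound 1 or fall nearer compound 4. For the compounds shown here, it also remains open whether the same exchange would carry a step of similar size on another compound of the series, since this is its only instance so far.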